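The source may hold more compounds than are shown below. What is called first, only, known or untested is meant among the compounds shown, and "the series" means these compounds.

Measured compounds:
Compound 1 `CC1CCN(Cc2ccc3nc(NC(=O)N/N=C/c4cn(Cc5ccccc5Cl)c5ccccc45)sc3c2)CC1` gives 1360 nM in a functional assay on MDA-MB-231 cells (Homo sapiens) for cytotoxicity, read by MTT assay, with a stated time of 72 h; a higher number here means a weaker inhibitor, a lower number a stronger inhibitor.
Compound 2 `CCN(CC)Cc1ccc2nc(NC(=O)N/N=C/c3cn(Cc4ccc(C)cc4)c4ccccc34)sc2c1` gives 2010 nM in this assay.
Compound 3 `Cc1ccc(Cn2cc(/C=N/NC(=O)Nc3nc4ccc(CN5CCC(C)CC5)cc4s3)c3ccccc32)cc1` gives 1140 nM in this assay.

On the numbers alone compound 2 has the largest value of the three, but its gaps to compound 1 and to compound 3 both sit within the scatter, so the three cannot be told apart with confidence. Compound 4 `CCN(CC)Cc1ccc2nc(NC(=O)N/N=C/c3cn(Cc4ccc(Cl)c(Cl)c4)c4ccccc34)sc2c1` is not yet measured. It differs from compound 2 in one place: 3,4-dichlorophenyl in place of 4-methylphenyl on a saturated chain carbon bound to an aromatic nitrogen.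

Within the data shown here, only one measured step touches the same place, the swap of groups on the saturated chain carbon bound to an aromatic nitrogen: a 1.2-fold lower number from compound 1 to compound 3 (0.08 log units; within the scatter). That step exchanged different groups than the one here, so it is a loose guide, but it shows that changing the substituent at this place moved nothing beyond the scatter. The other step, a 1.8-fold lower number from compound 2 to compound 3 (0.25 log units; within the scatter), concerns a different place and also stayed within the scatter. The expectation for compound 4 is therefore a step of a 1.1-fold lower number from compound 2 to compound 4 (0.02 log units; within the scatter), with no real change beyond the scatter. Compound 4 is estimated at 1900 nM, in the range 900 nM to 4000 nM.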

Compound 4, half-maximal inhibitory concentration: 4490 nM
Beside the measured number, compound 4's estimate is 2.4-fold (0.37 log units) below it; measured number outside the range, above it.
By their numbers in this assay, from the lowest: compounds 3, 1 and 2 (each within the scatter of the next); then compound 4.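

In this assay, among these compounds, putting 3,4-dichlorophenyl in place of 4-methylphenyl gives a 2.2-fold higher number from compound 2 to compound 4 (0.35 log units; beyond the scatter), the only step here that passes beyond the scatter. The group on the saturated chain carbon bound to an aromatic nitrogen can therefore shift the number, which the earlier swap at this place did not show, although this modest step rests on a single pair of compounds. Nothing measured here explains the shift.

On these data alone, it remains open whether both chlorines are needed for the shift or a phenyl ring with a single chlorine would show it too, and whether a pyridine ring or a methoxyphenyl group at this place would move the number either way. Also open, as far as these compounds go, is whether the same change has a similar effect when 4-methylpiperidin-1-yl replaces diethylamino.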